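Phenyl replacement in the sulfonylpyrrole methylamine series

A few compounds are considered here, and "the series" means these few. Any claim that something is new, unique, unknown or untested is made for them only; others in the source may bear on it.

Measured so far:
compound 1, `CNCc1cc(-c2ccccc2)n(S(=O)(=O)c2ccccc2)c1`: 96%
compound 2, `CNCc1cc(-c2cccnc2)n(S(=O)(=O)c2ccccc2)c1`: 4%

In a functional assay on the whole organism (strain Jcl:SD) for inhibition, with Rattus norvegicus as the target, with stated times of 3 min and 3 h, at a dose of 1 mg/kg by the intravenous route (a higher number here means more inhibition at the dose given (going by the name of the read-out), a lower number less inhibition), compound 1 gives 96%, the higher of the two numbers; compound 2 gives 4%. Among the compounds with values here, the single measured step, a number 92 percentage points lower from compound 1 to compound 2 (beyond the scatter), is large. Compound 3, `CNCc1cc(-c2cccnc2C#N)n(S(=O)(=O)c2ccccc2)c1`, has not been measured. It differs from compound 1 by 2-cyanopyridin-3-yl in place of phenyl on an aromatic carbon. Within the data shown here, the step from compound 1 to compound 2 bears directly on this change, since compound 3 also carries a pyridine ring at the same carbon; the added nitrile has no measured precedent here. A large downward step is therefore expected for compound 3, a number 81 percentage points lower from compound 1 to compound 3 (beyond the scatter), giving an estimated 15% with a range from 2% to 55%.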

Compound 3, a percentage reported as inhibition, in the whole organism at one dose (the size of the read-out at that dose, not a potency): 99%
Compound 3: middle estimate off by 84 percentage points, on the low side; the whole stated range lies below it.
By their numbers in this assay, from the lowest: compound 2; then compounds 1 and 3 (each within the scatter of the next).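

In this assay, within the data shown here, a pyridine ring at this carbon is not by itself a loss of inhibition: a number 95 percentage points higher from compound 2 to compound 3 (beyond the scatter), and the only change in that step is cyano in place of hydrogen. With 2-cyanopyridin-3-yl in place of phenyl, the step is a number 3 percentage points higher from compound 1 to compound 3 (within the scatter), so the nitrile-bearing pyridine and phenyl cannot be told apart at this dose. Nothing available explains the recovery.

As far as these compounds go, whether the recovery is specific to the nitrile remains open, as 2-methylpyridin-3-yl would test. Also open, from the compounds shown here alone, is what a 2-cyanophenyl group does without the pyridine nitrogen.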